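Expecting Little Change From One Group Swap

The source may report more compounds than this note shows. Statements on the series, on what has been measured and on what is new or still open speak of the compounds shown alone.

Among the measured compounds shown here, in a functional assay on HL-60 cells (Homo sapiens) for inhibition, read by CCK-8 assay, with a stated time of 48 h (on this read-out higher numbers stand for weaker inhibition and lower numbers for stronger inhibition), compound 1 (`Cc1ccc(-c2ccsc2S(=O)(=O)NCCNC(=S)Nc2ccc([N+](=O)[O-])cc2)c(Oc2ccc(O)c(O)c2)c1`) gives 2900 nM and compound 2 (`Cc1ccc(-c2ccsc2S(=O)(=O)NCCNC(=O)Nc2cc(Cl)cc(Cl)c2)c(Oc2ccc(O)c(O)c2)c1`) gives 3500 nM, so compound 2 stands within the usual scatter of the only other measured compound. Compound 3 (`Cc1ccc(-c2ccsc2S(=O)(=O)NCCNC(=S)Nc2cccc([N+](=O)[O-])c2)c(Oc2ccc(O)c(O)c2)c1`) differs from compound 2 in one place: a group of 12 heavy atoms (7 carbon, 2 nitrogen, 2 oxygen, 1 sulfur; one six-membered aromatic ring of carbon only) in place of a group of 11 heavy atoms (7 carbon, 1 nitrogen, 1 oxygen, 2 chlorine; one six-membered aromatic ring of carbon only), on an amine nitrogen. For the measured compounds named here, the one measured step that bears on this, a 1.2-fold higher number from compound 1 to compound 2 (0.08 log units; within the scatter), exchanged groups of the same atom counts in the opposite sense. That step stayed within the scatter, so no step beyond it is expected in this assay. This means an expected 1.2-fold lower number from compound 2 to compound 3 (0.07 log units; within the scatter). The estimate for compound 3 is 3000 nM, with an expected range of 1300 nM to 7000 nM.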

Compound 3, half-maximal inhibitory concentration: 3400 nM
Compound 3: the middle estimate sits 1.1-fold (0.05 log units) below what was measured, within the range that was stated.
By their numbers in this assay, from the lowest: compounds 1, 3 and 2 (each within the scatter of the next).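

In this assay, 3-nitrophenyl in place of 4-nitrophenyl on the amide-type nitrogen gives a 1.2-fold higher number from compound 1 to compound 3 (0.07 log units; within the scatter), so the placement of the nitro group, tested here alone, does not separate these two compounds. The wider exchange, which replaces (3,5-dichlorophenyl)carbamoyl on the amine nitrogen, gives a 1.0-fold lower number from compound 2 to compound 3 (0.01 log units; within the scatter), so this change does not separate its two compounds either. No measurement here explains why these values stay so close.

Going by these compounds, it remains open whether the values would stay this close with a group lacking an aromatic ring, such as a carboxylic acid or a plain butyl chain.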